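This account rests on a few compounds, and the source may have more. Where it says the series, first, only, none or still open, it means among the compounds named here.

Compound 1, `CCOC(=O)C1=C(N)Oc2ccc(C3CCCC3)cc2C1C(C#N)C(=O)OCC`: 128000 nM
Compound 2, `CCOC(=O)C1=C(N)Oc2ccc(CC)cc2C1C(C#N)C(=O)OCC`: 210000 nM

Both compounds were tested in an assay on isolated protein for binding affinity to Apoptosis regulator Bcl-2 (Homo sapiens), read by fluorescence polarization; on this read-out lower numbers stand for stronger inhibition and higher numbers for weaker inhibition. For the measured compounds named here, compound 2 holds the higher of the two numbers, but its only neighbour is compound 1, and the step of a 1.6-fold higher number from compound 1 to compound 2 (0.22 log units; within the scatter) is small enough that the two cannot be told apart. Compound 3, `CCOC(=O)C1=C(N)Oc2ccc(-c3ccccc3)cc2C1C(C#N)C(=O)OCC`, has not yet been measured; it differs from compound 2 in one place, (phenyl in place of ethyl on an aromatic carbon). Going by the values given here, the only measured step that speaks to this change is the exchange of one carbon-based group for another on the same aromatic carbon, a 1.6-fold higher number from compound 1 to compound 2 (0.22 log units; within the scatter), which stayed within the scatter. Nothing measured here involves an aromatic group at that position, so the guidance is thin. The expectation for compound 3 is therefore no step beyond the scatter, with the middle of the estimate lying a little below the number for compound 2 because compound 1, carrying the larger group, gave 128000 nM. For compound 3 the estimated value in this assay is 150000 nM, with a range from 50000 nM to 450000 nM. That estimate amounts to an expected step of a 1.4-fold lower number from compound 2 to compound 3 (0.15 log units; within the scatter).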

Compound 3, inhibition constant: 112000 nM
Beside the measured number, compound 3's estimate is 1.3-fold (0.13 log units) above it; the measured number falls inside the stated range.
By their numbers in this assay, from the lowest: compounds 3, 1 and 2 (each within the scatter of the next).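

For the compounds shown here, an aromatic group stands on this aromatic carbon for the first time, and in this assay phenyl in place of ethyl gives a 1.9-fold lower number from compound 2 to compound 3 (0.27 log units; within the scatter) and phenyl in place of cyclopentyl gives a 1.1-fold lower number from compound 1 to compound 3 (0.06 log units; within the scatter) on the same carbon. Ethyl has 2 heavy atoms and no ring, whereas phenyl has 6 heavy atoms in one six-membered aromatic ring, yet compound 1, compound 2 and compound 3 still cannot be told apart on this read-out. So far, neither adding a ring nor making that ring aromatic has produced a step beyond the scatter at this position, and no other information bears on why the numbers stay so close.

On these data alone, all three groups here consist of carbon and hydrogen only, so it remains open how an amine, a carboxylic acid or a methoxy group would behave on this carbon. Also open, as far as these compounds go, is whether any group here, including a phenyl with its own added group such as a chlorine atom, can move the number beyond the scatter.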